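The source may report more compounds than this note shows. Statements on the series, on what has been measured and on what is new or still open speak of the compounds shown alone.

Compound 1, `O=C(CCCCCCc1ccccc1)c1nnn[nH]1`, is a ketone in which a chain of six carbons linking a phenyl ring ends on a tetrazole. In an assay on HEK-293T cells for inhibition of diacylglycerol lipase-alpha (Homo sapiens), read by colorimetric assay (a higher number here means a weaker inhibitor, a lower number a stronger inhibitor), compound 1 gives only a limit, > 10000 nM; > 10000 nM (2 entries), so no number is known for it. Compound 2, `CC(C)(C)C(=O)c1coc(C(=O)CCCCCCc2ccccc2)n1`, keeps the same phenyl-bearing ketone chain but carries it on a different five-membered core that also bears a (tert-butyl)carbonyl group. In this assay, among the measured compounds shown here, compound 2 gives 479 nM, the only number among the compounds measured so far. Compound 3, `O=C(CCCCCCc1ccccc1)c1nc(Br)co1`, differs from compound 2 in one place: bromo in place of (tert-butyl)carbonyl on an aromatic carbon. For the measured compounds named here, no measured pair shows a step of this kind, so the size of the change is open. Compound 3 is expected to be a weaker inhibitor, with a step of a 6.3-fold higher number from compound 2 to compound 3 (0.80 log units; beyond the scatter) from compound 2 to compound 3, and its estimate is 3000 nM, within 800 nM to 12000 nM.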

Compound 3, half-maximal inhibitory concentration: > 10000 nM
Compound 3: a limit, no number (the forecaster's own chance of this, stated with the estimate: 35%); at least 3.3-fold (0.52 log units) between middle value and limit.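

Among the compounds shown here, until now no measured pair showed what this position on the aromatic carbon contributes. Putting bromo in place of (tert-butyl)carbonyl gives an at least 20-fold higher number from compound 2 to compound 3 (1.31 log units; beyond the scatter), so with the chain and the rest of the core unchanged, inhibition in this assay depends strongly on the group held here. Compound 3 gives > 10000 nM, which is a limit and not a number, so the step has a floor but no known size: the limit of > 10000 nM in this assay, at which 1 of the 3 values shown sits.

The change removes the carbonyl and the tert-butyl part together, so the compounds shown cannot tell which of them matters, or whether both do. A tert-butyl group without the carbonyl, an acetyl group or a methyl ester at this place would be needed to separate the two parts.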